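Methylation of the ring nitrogen: from compound 2 to compound 4

A few compounds are considered here, and "the series" means these few. Any claim that something is new, unique, unknown or untested is made for them only; others in the source may bear on it.

Of the compounds shown here, three of the shared core have been measured. In an assay on isolated protein for inhibition of RAC-alpha serine/threonine-protein kinase (Homo sapiens), tested at 30 uM (a higher number here means more inhibition at the concentration tested (going by the name of the read-out), a lower number less inhibition), compound 1 `Cn1cnc2c(Nc3ccc(F)cc3)ncnc21` gives 0%. Compound 2 `c1ccc(Sc2ncnc3[nH]cnc23)cc1` gives 0% in this assay, and compound 3 `Fc1ccc(Sc2ncnc3[nH]cnc23)cc1` gives 0%. Compound 2 thus stands level with compounds 1 and 3 at the digits shown. For the measured compounds named here, the only measured step, no change at the digits printed from compound 2 to compound 3 (within the scatter), puts fluoro in place of hydrogen on an aromatic carbon and stays within the scatter. Compound 4 `Cn1cnc2c(Sc3ccccc3)ncnc21` differs from compound 2 by methyl in place of hydrogen on an aromatic nitrogen. Going by the values given here, no measured step touches the aromatic nitrogen; compound 1 carries the methyl there and gives 0%, within the scatter of compound 2. Compound 4 is therefore expected to show no step beyond the scatter, no change at the digits printed from compound 2 to compound 4 (within the scatter). The estimate for compound 4 is 0%, between -10% and 10%.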

Compound 4, a percentage reported as inhibition, at one concentration (the size of the read-out at that concentration, not a potency): 0%
The estimate for compound 4 equals the measured number at the digits printed; low and high end bracket the measured number.
By their numbers in this assay, from the lowest: compounds 1, 2, 3 and 4 (each within the scatter of the next).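

Methyl in place of hydrogen on the aromatic nitrogen now has a direct reading in this assay: no change at the digits printed from compound 2 to compound 4 (within the scatter). Compound 2 already reads 0%, so this step cannot show whether the methyl would matter on a compound with measurable inhibition. No available measurement offers an explanation for the flat result. As far as these compounds go, it remains open whether a longer chain such as propyl, or a chain ending in an amine, on this nitrogen would raise the read-out in this assay.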